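A few compounds are considered here, and "the series" means these few. Any claim that something is new, unique, unknown or untested is made for them only; others in the source may bear on it.

Working notes on the series. The measured set is compound 1 `CC1=C(O)[C@@H](C/C(C)=C\CC[C@H](C)/C=C/C=C(\C)CCCc2ccoc2)OC1=O`, compound 2 `CC1=C(O)[C@@H](C/C(C)=C\CC[C@H](C)/C=C/C=C(\C)CCCC2=CCN(CCC(C)C)C2=O)OC1=O` and compound 3 `CCC(C)CN1CC=C(CCC/C(C)=C/C=C/[C@@H](C)CC/C=C(/C)C[C@H]2OC(=O)C(C)=C2O)C1=O`. In a functional assay on SK-OV-3 cells (Homo sapiens) for cytotoxicity (on this read-out higher numbers stand for an effect only at larger amounts of compound and lower numbers for an effect already at smaller amounts), compound 1 gives 9.6 ug/mL, the second highest of the three numbers; compound 2 gives 4 ug/mL and compound 3 gives 26.8 ug/mL. The two steps from compound 1 both lie beyond the scatter: a 2.4-fold lower number from compound 1 to compound 2 (0.38 log units; beyond the scatter) and a 2.8-fold higher number from compound 1 to compound 3 (0.45 log units; beyond the scatter). The step between the two amide-bearing compounds is the largest one seen, a 6.7-fold higher number from compound 2 to compound 3 (0.83 log units; beyond the scatter).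

Compound 4 `COC(=O)C(O)C/C(C)=C\CC[C@H](C)/C=C/C=C(\C)CCCc1ccoc1` is not yet measured. It differs from compound 1 at the opposite end of the chain from where compounds 2 and 3 differ: a group of 6 heavy atoms (3 carbon, 3 oxygen; no ring) in place of a group of 8 heavy atoms (5 carbon, 3 oxygen; one five-membered non-aromatic ring with 1 hetero atom), on a saturated chain carbon bound to a double-bonded chain carbon. None of the three measured steps touches the group that leaves here; all of them concern the group on the saturated chain carbon three bonds along the chain from a double-bonded chain carbon, or the substituent on the amide-type nitrogen. The data therefore give no direct guide to the size or direction of the change in this assay, and the expectation rests only on the fact that the common core of compounds 1 to 3 is no longer present. A higher number, beyond the scatter, is expected, with a wide range: a 2.9-fold higher number from compound 1 to compound 4 (0.46 log units; beyond the scatter). Compound 4 is estimated at 28 ug/mL, between 8 ug/mL and 90 ug/mL.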

Compound 4, concentration for half-maximal effect: 10 ug/mL
The estimate for compound 4 lay 2.8-fold (0.45 log units) above the measured number; the range from low to high includes it.
By their numbers in this assay, from the lowest: compound 2; then compounds 1 and 4 (each within the scatter of the next); then compound 3.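

Within the data shown here, the change from the group in compound 1 to hydroxy(methoxycarbonyl)methyl, on a saturated chain carbon bound to a double-bonded chain carbon, is the first one seen at this end of the chain, and in this assay it amounts to a 1.0-fold higher number from compound 1 to compound 4 (0.02 log units; within the scatter). In this pair, then, the five-membered non-aromatic ring and its defined stereocentre can give way to an open group with the same count of hydrogen-bond donors and acceptors while the number stays within the scatter, whereas a change at the other end of the chain, seen in a 6.7-fold higher number from compound 2 to compound 3 (0.83 log units; beyond the scatter), lies beyond it. No measured property is at hand that bears on this result.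

Whether hydroxy(methoxycarbonyl)methyl would leave the numbers equally unmoved alongside the amide-bearing chain ends of compound 2 and compound 3 remains open, since it is shown here only with the chain end of compound 1. Also open, going by these compounds, is how a carboxylic acid in place of the methyl ester, or an amine in place of the hydroxy group, would read in this assay.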